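Replacing a nitrile with a second tetrazole variant

The compounds below may be only part of what the source reports. "The series", "measured", "known", "first", "only" and "open" are said of these compounds alone.

Three compounds share one core and differ only in the group carried on an aromatic carbon of the outer ring. Compound 1 `CC(O)Cn1nnnc1-c1ccccc1-c1ccc(CN2C(=O)[C@H](NC(=O)CC(C)(C)N)CCc3ccccc32)cc1` carries a 1-(2-hydroxypropyl)-1H-tetrazol-5-yl group, and in a functional assay (Pituitary gland cell) with Rattus norvegicus as the target (on this read-out lower numbers stand for an effect already at smaller amounts and higher numbers for an effect only at larger amounts of compound), compound 1 gives 0.05 uM. Compound 2 `CC(C)(N)CC(=O)N[C@@H]1CCc2ccccc2N(Cc2ccc(-c3ccccc3S(N)(=O)=O)cc2)C1=O` carries a sulfamoyl group instead, and in this assay compound 2 gives 3 uM. Compound 3 `CC(C)(N)CC(=O)N[C@@H]1CCc2ccccc2N(Cc2ccc(-c3ccccc3C#N)cc2)C1=O` carries a cyano group, and in this assay compound 3 gives 5 uM, the highest of the three numbers; it stands close to compound 2, with a 1.7-fold higher number from compound 2 to compound 3 (0.22 log units; within the scatter), and far from compound 1, with a 100-fold higher number from compound 1 to compound 3 (2.00 log units; beyond the scatter).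

Compound 4 `CC(C)(N)CC(=O)N[C@@H]1CCc2ccccc2N(Cc2ccc(-c3ccccc3-c3nnnn3CC(=O)O)cc2)C1=O` is the next step from compound 3: 1-(carboxymethyl)-1H-tetrazol-5-yl in place of cyano on an aromatic carbon. This change brings back a tetrazole ring of the kind found in compound 1, though with a carboxymethyl chain rather than a hydroxypropyl one. Among the measured compounds shown here, the step that bears on it most is the one from compound 1 to compound 3, where the loss of the tetrazole gave a large rise in the number, and also the step from compound 1 to compound 2, a 60-fold higher number from compound 1 to compound 2 (1.78 log units; beyond the scatter). The reverse change is therefore expected to lower the number strongly, with a 50-fold lower number from compound 3 to compound 4 (1.70 log units; beyond the scatter) as the expected step. For compound 4 the estimate in this assay is 0.1 uM, within a range from 0.02 uM to 0.6 uM.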

Compound 4, concentration for half-maximal effect: 1 uM
For compound 4 the middle estimate is 10-fold (1.00 log units) below the measured one; measured number outside the range, above it.
By their numbers in this assay, from the lowest: compound 1; then compound 4; then compounds 2 and 3 (each within the scatter of the next).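

In this assay, a tetrazole bearing a carboxymethyl chain on this aromatic carbon gives a lower number than either smaller group, with a 5.0-fold lower number from compound 3 to compound 4 (0.70 log units; beyond the scatter) and a 3.0-fold lower number from compound 2 to compound 4 (0.48 log units; beyond the scatter) on this read-out, so the gain over cyano and sulfamoyl is real but modest. The end of the chain on the tetrazole turns out to matter more than that gain: with the ring kept, carboxy in place of 1-hydroxyethyl gives a 20-fold higher number from compound 1 to compound 4 (1.30 log units; beyond the scatter) in this read-out, so the tetrazole ring alone does not bring the low number of compound 1. Nothing measured here explains why the end of this chain counts for so much.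

The compounds shown leave open how a tetrazole with no chain at all would compare, and so how much of the effect belongs to the ring and how much to the chain. They also leave open whether a methyl ester, a primary amide or an amine at the chain end would come closer to the hydroxypropyl chain of compound 1 than the carboxylic acid does.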